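Cytotoxicity of benzothiophene sulfonamides: a methyl for bromo

A few compounds are considered here, and "the series" means these few. Any claim that something is new, unique, unknown or untested is made for them only; others in the source may bear on it.

The series shares a sulfonamide core, shown in compound 3 `O=S(=O)(NCc1cc2ccccc2s1)c1ccc(Br)cc1`, which carries a bromo group on its aryl ring. Compound 1 `O=[N+]([O-])c1ccc(S(=O)(=O)NCc2cc3ccccc3s2)cc1` carries a nitro group in the same position, and compound 2 `O=S(=O)(NCc1cc2ccccc2s1)c1ccc(F)cc1` a fluoro group. In an ADME assay on MDCK cells (Canis lupus familiaris) for cytotoxicity, read by MTT assay, with a stated time of 24 h (on this read-out higher numbers stand for lower toxicity in this test and lower numbers for higher toxicity in this test), compound 3 reaches only the limit of the test, > 174000 nM. Compound 1 likewise gives only a limit in this assay, > 191000 nM. For compound 2 this assay reports "not determined" (no result reported). Among the measured compounds shown here, the one step between measured compounds, a step that the two limits leave unreadable from compound 1 to compound 3, cannot be read because both ends are limits, the limit of > 174000 nM in this assay, at which 1 of the 3 values shown sits, and (the limit of > 191000 nM in this assay, at which 1 of the 3 values shown sits), so no measured step gives a direction for the next change.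

Compound 4 `Cc1ccc(S(=O)(=O)NCc2cc3ccccc3s2)cc1` differs from compound 3 by methyl in place of bromo on an aromatic carbon. With both neighbouring values sitting at limits, the expected step that the limit leaves unreadable from compound 3 to compound 4 is none beyond the scatter. Compound 4 is therefore estimated to give 200000 nM in this assay, within the range 60000 nM to 600000 nM, and most probably again only a limit.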

Compound 4, half-maximal cytotoxic concentration: > 210000 nM
Compound 4: only a limit was reported; the forecaster's own chance of this, stated with the estimate: 80%; middle value at least 1.0-fold (0.02 log units) from the limit.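

Compound 4 gives only a limit in this assay, > 210000 nM. The steps to compound 4 from compound 1 and compound 3 therefore cannot be read. The compounds shown leave open whether any of these aryl groups changes the half-maximal cytotoxic concentration at all.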